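The source may hold more compounds than are shown below. What is called first, only, known or untested is meant among the compounds shown, and "the series" means these compounds.

Compound 1 `COc1ccc(-c2c(C(=O)c3cc(OC)c(OC)c(OC)c3)sc3ccccc23)cc1` sets the starting point of this small set. In a functional assay on HL-60 cells (Homo sapiens) for antiproliferative activity, read by MTT assay, with a stated time of 72 h (on this read-out higher numbers stand for weaker inhibition and lower numbers for stronger inhibition), compound 1 gives 1600 nM. Compound 2 `CCOc1ccc(-c2c(C(=O)c3cc(OC)c(OC)c(OC)c3)sc3ccccc23)cc1` differs from it by a single change, (methyl in place of hydrogen on a saturated chain carbon bound to an oxygen on an aromatic ring), and in this assay compound 2 gives 3500 nM, which amounts to a 2.2-fold higher number from compound 1 to compound 2 (0.34 log units; beyond the scatter). Compound 3 `COc1ccc(Nc2c(C(=O)c3cc(OC)c(OC)c(OC)c3)sc3ccccc23)cc1` keeps the methoxy end but changes the core: (4-methoxyphenyl)amino in place of 4-methoxyphenyl on an aromatic carbon. In this assay compound 3 gives 3700 nM, the highest number of the three, which is a 2.3-fold higher number from compound 1 to compound 3 (0.36 log units; beyond the scatter), while against compound 2 the gap is only a 1.1-fold higher number from compound 2 to compound 3 (0.02 log units; within the scatter).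

Compound 4 `CCOc1ccc(Nc2c(C(=O)c3cc(OC)c(OC)c(OC)c3)sc3ccccc23)cc1` has not yet been measured. It stands to compound 3 as compound 2 stands to compound 1: the change is methyl in place of hydrogen on a saturated chain carbon bound to an oxygen on an aromatic ring, and the place described for it is the same word for word in both pairs, so it is the same change. The two cores differ in the way already described for compound 3. Where this change was measured it gave a 2.2-fold higher number from compound 1 to compound 2 (0.34 log units; beyond the scatter), a modest loss, and the same direction and size are expected here, since nothing in the set shows the two cores answering the change differently. The expected step is therefore a 2.0-fold higher number from compound 3 to compound 4 (0.31 log units; beyond the scatter), resting on the step of a 2.2-fold higher number from compound 1 to compound 2 (0.34 log units; beyond the scatter) seen with compound 1 and compound 2. Compound 4 is expected to give 7500 nM in this assay, estimated to lie between 3500 nM and 16000 nM.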

Compound 4, half-maximal inhibitory concentration: 500 nM
Compound 4: middle estimate off by 15-fold (1.18 log units), on the high side; measured number outside the range, below it.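

In this assay, the methyl that turns methoxy into ethoxy gives a 7.4-fold lower number from compound 3 to compound 4 (0.87 log units; beyond the scatter), so on the core of compound 3 it acts in the opposite direction to its effect on the core of compound 1: the same change on two cores in this assay, a 2.2-fold higher number (0.34 log units; beyond the scatter) from compound 1 to compound 2 and a 7.4-fold lower number (0.87 log units; beyond the scatter) from compound 3 to compound 4, 16-fold (1.21 log units) apart, beyond the scatter of two such steps. The two cores also rank differently depending on the end group: with the ethoxy end, moving to (4-ethoxyphenyl)amino gives a 7.0-fold lower number from compound 2 to compound 4 (0.85 log units; beyond the scatter), and compound 4 also stands clear of compound 1, with a 3.2-fold lower number from compound 1 to compound 4 (0.51 log units; beyond the scatter), whereas with the methoxy end the amino-linked compound is the weaker one, with a 2.3-fold higher number from compound 1 to compound 3 (0.36 log units; beyond the scatter). For the compounds shown here, this shows that the effect of this change cannot be carried from one core to the other, but with only one pair on each core it does not show why the two differ, nor whether any other change would diverge in the same way.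

The compounds shown leave open whether the gain at compound 4 is particular to ethoxy or would continue with a longer chain such as propoxy or butoxy on the same core. They also leave open how a hydroxyl group or an amine at that end would behave on each of the two cores.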